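The source may report more compounds than this note shows. Statements on the series, on what has been measured and on what is new or still open speak of the compounds shown alone.

Compound 1 `COC(=O)c1scc(-c2ccc(NC(=O)c3cccc(C(F)(F)F)c3)cc2)c1OC` gives 32500 nM
Compound 2 `COC(=O)c1scc(-c2ccc(NC(=O)c3ccc(C(F)(F)F)cc3Br)cc2)c1OC` gives 28200 nM

Both values come from a functional assay on HepG2 cells (Homo sapiens) for antiproliferative activity, read by MTT assay, with a stated time of 24 h; on this read-out higher numbers stand for weaker inhibition and lower numbers for stronger inhibition. On these numbers, compound 2 stands within the usual scatter of compound 1, so the two cannot be ranked. Compound 3 `COC(=O)c1scc(-c2ccc(NC(=O)c3ccc(C(F)(F)F)cc3)cc2)c1OC` differs from compound 2 in one place, with hydrogen in place of bromo on an aromatic carbon. Within the data shown here, no two measured compounds differ in one place only, so the size of this change has not been observed directly. The only indirect hint is that compound 1, which also carries no bromo, gives 32500 nM in the same test. A step beyond the scatter in this assay is therefore not expected, in either direction. The expected change is a 1.1-fold higher number from compound 2 to compound 3 (0.03 log units; within the scatter). For compound 3 the estimated value is 30000 nM, with an expected range from 14000 nM to 62000 nM.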

Compound 3, half-maximal inhibitory concentration: 24600 nM
Compound 3: middle estimate off by 1.2-fold (0.09 log units), on the high side; measured number inside the range.
By their numbers in this assay, from the lowest: compounds 3, 2 and 1 (each within the scatter of the next).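

In this assay, among these compounds, the step with hydrogen in place of bromo on an aromatic carbon, ortho to a large group and meta to a trifluoromethyl group, is a 1.1-fold lower number from compound 2 to compound 3 (0.06 log units; within the scatter), the first direct reading at this position, and it does not separate the two atoms. The step with 4-(trifluoromethyl)phenyl in place of 3-(trifluoromethyl)phenyl on a carbonyl carbon is a 1.3-fold lower number from compound 1 to compound 3 (0.12 log units; within the scatter), so the two placings of the trifluoromethyl group cannot be ranked either. Nothing measured here bears on why these steps are so small.

As far as these compounds go, it remains open whether an amine or a carboxylic acid on that same aromatic carbon would give a step beyond the scatter. From the compounds shown here alone, it is also open whether a free carboxylic acid in place of the methyl ester of the shared core would do so.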